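This account rests on a few compounds, and the source may have more. Where it says the series, first, only, none or still open, it means among the compounds named here.

Compounds measured in a functional assay on K562 cells (Homo sapiens) for antiproliferative activity, read by MTT assay, with a stated time of 48 h; a lower number here means a stronger inhibitor, a higher number a weaker inhibitor:
Compound 1 `COc1ccc(-c2ccc3c(c2)C(=O)C(=O)N3C)cc1` gives 4980 nM.
Compound 2 `COc1ccc(-c2ccc3c(c2)C(=O)C(=O)N3Cc2ccc(Cl)cc2)cc1` gives 350 nM.
Compound 3 `COc1ccc(-c2ccc3c(c2)C(=O)C(=O)N3Cc2ccc(C)cc2)cc1` gives 270 nM.

Compound 3 has the lowest of the three numbers in this assay, but the gap to compound 2 is within the scatter (a 1.3-fold lower number from compound 2 to compound 3 (0.11 log units; within the scatter)), and only compound 1 lies clearly apart (an 18-fold lower number from compound 1 to compound 3 (1.27 log units; beyond the scatter)). Compound 4 `COc1ccc(-c2ccc3c(c2)C(=O)C(=O)N3Cc2ccc(OC)c(OC)c2)cc1` differs from compound 3 in one place: 3,4-dimethoxyphenyl in place of 4-methylphenyl on a saturated chain carbon bound to an amide-type nitrogen in a ring. For the measured compounds named here, two steps bear on this. Adding a substituted phenyl to that carbon was large (a 14-fold lower number from compound 1 to compound 2 (1.15 log units; beyond the scatter) and an 18-fold lower number from compound 1 to compound 3 (1.27 log units; beyond the scatter)), while changing the group on that phenyl was not (a 1.3-fold lower number from compound 2 to compound 3 (0.11 log units; within the scatter)). The change to compound 4 only alters what sits on the added ring, so no step beyond the scatter is expected in this assay. The expected step is a 1.2-fold higher number from compound 3 to compound 4 (0.07 log units; within the scatter). Compound 4 is estimated at 320 nM, ranging from 130 nM to 800 nM.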

Compound 4, half-maximal inhibitory concentration: 60 nM
Compound 4: the middle estimate sits 5.3-fold (0.73 log units) above what was measured; measured number below the stated range.
By their numbers in this assay, from the lowest: compound 4; then compounds 3 and 2 (each within the scatter of the next); then compound 1.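

In this assay, the group on the added phenyl ring now matters at this position, on a saturated chain carbon bound to an amide-type nitrogen in a ring. Moving to 3,4-dimethoxyphenyl gives a 4.5-fold lower number from compound 3 to compound 4 (0.65 log units; beyond the scatter) and a 5.8-fold lower number from compound 2 to compound 4 (0.77 log units; beyond the scatter), and the full change from hydrogen gives an 83-fold lower number from compound 1 to compound 4 (1.92 log units; beyond the scatter). Nothing measured here gives a reason for this gain.

The compounds shown leave open whether a single methoxy group on that ring would be enough. They also leave open how an amine or a carboxylic acid there would behave.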